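Amide substituent variation at the shared core

The source may report more compounds than this note shows. Statements on the series, on what has been measured and on what is new or still open speak of the compounds shown alone.

Three amides on the shared core have been measured in a functional assay on PC-3 cells (Homo sapiens) for antiproliferative activity, read by MTT assay, with a stated time of 24 h; a lower number here means a stronger inhibitor, a higher number a weaker inhibitor. Compound 1 `CCn1c(C(=O)N[C@@H](C)C(=O)OC)ccc1C(CC)(CC)c1ccc(OCS(=O)(=O)c2ccccc2)c(C)c1` carries a 1-(methoxycarbonyl)ethyl group on the amide nitrogen; in this assay compound 1 reaches only the limit > 50000 nM, a limit and not a number (the limit of > 50000 nM in this assay, at which 1 of the 3 values shown sits). Compound 2 `CCn1c(C(=O)NCCO)ccc1C(CC)(CC)c1ccc(OCS(=O)(=O)c2ccccc2)c(C)c1` gives 17700 nM. Compound 3 `CCn1c(C(=O)N[C@H](CO)C(C)C)ccc1C(CC)(CC)c1ccc(OCS(=O)(=O)c2ccccc2)c(C)c1` gives 7300 nM, the lowest of the two numbers, with the step of a 2.4-fold lower number from compound 2 to compound 3 (0.38 log units; beyond the scatter) beyond the scatter. The other steps are an at least 2.8-fold lower number from compound 1 to compound 2 (0.45 log units; beyond the scatter) and an at least 6.8-fold lower number from compound 1 to compound 3 (0.83 log units; beyond the scatter).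

Compound 4 `CCn1c(C(=O)N[C@H](C)C(=O)O)ccc1C(CC)(CC)c1ccc(OCS(=O)(=O)c2ccccc2)c(C)c1` is the next member. The change from compound 3 is 1-carboxyethyl in place of 1-(hydroxymethyl)-2-methylpropyl on an amide-type nitrogen. Within the data shown here, it largely runs back along the step that separates compound 1 from compound 3, with the methyl ester of compound 1 replaced by the free acid; no measured pair isolates that ester-to-acid change. Given the step of an at least 6.8-fold lower number from compound 1 to compound 3 (0.83 log units; beyond the scatter) and the step of a 2.4-fold lower number from compound 2 to compound 3 (0.38 log units; beyond the scatter), a higher number is expected for compound 4, with the chance that only a limit is returned. The expected step is a 4.1-fold higher number from compound 3 to compound 4 (0.61 log units; beyond the scatter). Compound 4 is estimated at 30000 nM, within 8000 nM to 150000 nM.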

Compound 4, half-maximal inhibitory concentration: 20100 nM
Compound 4: the middle estimate sits 1.5-fold (0.17 log units) above what was measured, within the range that was stated.
By their numbers in this assay, from the lowest: compound 3; then compounds 2 and 4 (each within the scatter of the next). At a limit, above all of these: compound 1.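

On the amide-type nitrogen, 1-carboxyethyl in place of 1-(methoxycarbonyl)ethyl gives an at least 2.4-fold lower number from compound 1 to compound 4 (0.39 log units; beyond the scatter) in this assay, but the stereocentre of this group is drawn with opposite configuration in the two structures, and the step does not isolate ester against free acid. Compound 1 stands at a limit and not a number: the limit of > 50000 nM in this assay, at which 1 of the 4 values shown sits. 1-Carboxyethyl and 2-hydroxyethyl are not separated, with a 1.1-fold higher number from compound 2 to compound 4 (0.06 log units; within the scatter), whereas 1-(hydroxymethyl)-2-methylpropyl keeps the lower number against 1-carboxyethyl, with a 2.8-fold higher number from compound 3 to compound 4 (0.44 log units; beyond the scatter).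

Still open, from the compounds shown here alone, is how a 2-aminoethyl or a 3-hydroxypropyl group on this nitrogen would read. Among these compounds, also open is whether the lower number of compound 3 goes with its isopropyl branch, since no pair here separates that branch from the hydroxymethyl group.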